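The compounds below may be only part of what the source reports. "The series", "measured", "known", "first", "only" and "open" are said of these compounds alone.

For the measured compounds named here, in a functional assay on DU-145 cells (Homo sapiens) for inhibition, read by trypan blue exclusion, with a stated time of 96 h (on this read-out lower numbers stand for stronger inhibition of growth and higher numbers for weaker inhibition of growth), compound 3 `Cc1ccc(S(=O)(=O)/C(=C/c2ccc(Br)cc2)C(=O)c2ccc(Br)cc2)cc1` gives 10000 nM, the lowest number so far, while compound 1 `COc1ccc(/C=C(\C(=O)c2ccc(Br)cc2)S(=O)(=O)c2ccc(Br)cc2)cc1` gives 25000 nM. Compound 2 `Cc1ccc(S(=O)(=O)/C(=C/c2c(O)cc(O)cc2O)C(=O)c2ccc(Br)cc2)cc1` gives > 100000 nM, which is a limit of the assay. Compound 4 `COc1ccc(/C=C(\C(=O)c2ccc(Br)cc2)S(=O)(=O)c2ccc(C)cc2)cc1` keeps the rest of compound 3 but has methoxy in place of bromo on an aromatic carbon, so that 4-bromophenyl becomes 4-methoxyphenyl. Going by the values given here, only one measured step touches this group: an at least 10-fold lower number from compound 2 to compound 3 (1.00 log units; beyond the scatter). That step brought in the 4-bromophenyl group, but it starts from a limit and from a different group, so it shows that the position matters without fixing a size for this change. The nearer guide is compound 1, which already carries 4-methoxyphenyl and gives 25000 nM, although it also differs from compound 4 in its other aromatic ring. A modest rise is therefore expected in this assay, estimated as a 2.2-fold higher number from compound 3 to compound 4 (0.34 log units; beyond the scatter). The expected value for compound 4 is 22000 nM, with an estimated range from 9000 nM to 55000 nM.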

Compound 4, concentration for 50% growth inhibition: 1000 nM
Compound 4: the middle estimate sits 22-fold (1.34 log units) above what was measured, and the stated range ends above it.
By their numbers in this assay, from the lowest: compound 4; then compound 3; then compound 1. At a limit, above all of these: compound 2.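

In this assay, a 10-fold lower number from compound 3 to compound 4 (1.00 log units; beyond the scatter) shows that methoxy at this place, on the aromatic carbon para to a large group, is not a loss against bromo but a clear gain when the other aromatic ring carries methyl. The same 4-methoxyphenyl group depends strongly on that other ring, with a 25-fold lower number from compound 1 to compound 4 (1.40 log units; beyond the scatter) marking what methyl in place of bromo does there. Compound 2 stands at a limit of the assay, and 4-methoxyphenyl in place of its 2,4,6-trihydroxyphenyl gives an at least 100-fold lower number from compound 2 to compound 4 (2.00 log units; beyond the scatter) as a bound rather than a size: the limit of > 100000 nM in this assay, at which 1 of the 4 values shown sits.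

The compounds shown leave open whether an amine, a single hydroxy or a longer chain such as ethoxy at this place would lower the number further. They also leave open whether the gain from methoxy survives a carboxylic acid on the other aromatic ring.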